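Deacetylated thiadiazole glycoside with a terminal alkene

This account rests on a few compounds, and the source may have more. Where it says the series, first, only, none or still open, it means among the compounds named here.

Measured compounds:
compound 1, `CCCCCCCCCCCC(=O)Nc1nnc(S[C@@H]2O[C@H](COC(C)=O)[C@H](OC(C)=O)[C@H](OC(C)=O)[C@H]2OC(C)=O)s1`, 16900 nM
compound 2, `C=CCCCCCCCCC(=O)Nc1nnc(S[C@@H]2O[C@H](COC(C)=O)[C@H](OC(C)=O)[C@H](OC(C)=O)[C@H]2OC(C)=O)s1`, 22900 nM
compound 3, `CCCCCCCCCCCC(=O)Nc1nnc(S[C@@H]2O[C@H](CO)[C@H](O)[C@H](O)[C@H]2O)s1`, "not active" (no number reported)

In a functional assay on DU-145 cells (Homo sapiens) for cytotoxicity, read by MTT assay, with a stated time of 24 h (a higher number here means a weaker inhibitor, a lower number a stronger inhibitor), compound 1 gives 16900 nM and compound 2 gives 22900 nM. The change between them is vinyl in place of propyl on a saturated chain carbon, eight bonds along the chain from a carbonyl carbon, and the step is a 1.4-fold higher number from compound 1 to compound 2 (0.13 log units; within the scatter). Compound 3 is reported in this assay only as "not active" (no number reported), with no number given. The difference between the core of compound 1 and the core of compound 3 is not broken down here. Compound 4, `C=CCCCCCCCCC(=O)Nc1nnc(S[C@@H]2O[C@H](CO)[C@H](O)[C@H](O)[C@H]2O)s1`, is not yet measured; it differs from compound 3 by vinyl in place of propyl on a saturated chain carbon, eight bonds along the chain from a carbonyl carbon, the same kind of change as from compound 1 to compound 2, at the same place. Since that earlier step lay within the scatter, compound 4 is expected to stand close to compound 3 in this assay, with a fair chance that again only a limit is reported. The estimate for compound 4 is 80000 nM, between 25000 nM and 300000 nM.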

Compound 4, half-maximal inhibitory concentration: "not active" (no number reported)
No number was reported for compound 4; there is nothing to compare the estimate with.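

In this assay compound 3 ("not active" (no number reported)) and compound 4 ("not active" (no number reported)) carry no numbers, so no new step can be read between them. No available data bear on this result. The compounds shown leave open what vinyl in place of propyl does on the core of compound 3.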